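A Benzimidazole Replaces the Nitrophenyl on the Sulfur Arm

A few compounds are considered here, and "the series" means these few. Any claim that something is new, unique, unknown or untested is made for them only; others in the source may bear on it.

Compound 1 `Cc1cc(Nc2ccc(C(=O)/C=C/c3cccc(Br)n3)cc2)n2nc(SCc3ccc([N+](=O)[O-])cc3)nc2n1` stands highest of the two compounds measured in a functional assay on MGC-803 cells (Homo sapiens) for inhibition, read by sulforhodamine B assay, with a stated time of 72 h, tested at 10 uM; on this read-out lower numbers stand for less inhibition and higher numbers for more inhibition at the one concentration tested (going by the name of the read-out). In this assay compound 1 gives 91.6%, while compound 2 `C#CCSc1nc2nc(-c3ccccc3)cc(Nc3ccc(C(=O)/C=C/c4cccc(Br)n4)cc3)n2n1` gives 56.3%, a gap beyond the scatter. Compound 3 `Cc1cc(Nc2ccc(C(=O)/C=C/c3cccc(Br)n3)cc2)n2nc(SCc3nc4ccccc4[nH]3)nc2n1` differs from compound 1 in one place: 1H-benzimidazol-2-yl in place of 4-nitrophenyl on a saturated chain carbon bound to a sulfur. Within the data shown here, no measured pair shows this kind of change, so its size cannot be read from the data. The step of a number 9.6 percentage points lower from compound 1 to compound 3 (within the scatter) is expected to be small, downward if anything, and close to the usual scatter. Compound 3 is therefore estimated at 82%, with a range from 58% to 96%.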

Compound 3, a percentage reported as inhibition, at one concentration (the size of the read-out at that concentration, not a potency): 94.4%
For compound 3 the middle estimate is 12.4 percentage points below the measured one, within the range that was stated.
By their numbers in this assay, from the lowest: compound 2; then compounds 1 and 3 (each within the scatter of the next).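

In this assay, among these compounds, the exchange of 4-nitrophenyl for 1H-benzimidazol-2-yl on a saturated chain carbon bound to a sulfur gives a number 2.8 percentage points higher from compound 1 to compound 3 (within the scatter) and is the first step read at this position. This position thus accepts a group with a five-membered aromatic ring and a hydrogen-bond donor in place of a group with neither, while the values stay within the scatter. No measured evidence bears on this result. Going by these compounds, whether an amine, a carboxylic acid or a longer chain would be accepted here stays open. The single concentration also leaves open whether compound 1 and compound 3 differ in potency.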